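Swapping the Ring on the Amine Nitrogen

The source may hold more compounds than are shown below. What is called first, only, known or untested is meant among the compounds shown, and "the series" means these compounds.

Compound 1, `O=C(CN1CCN(c2ccncc2)CC1)Nc1nc2c(s1)CCCC2`, in an assay on isolated protein for inhibition of long-chain fatty acid transport protein 1 (Mus musculus), read by scintillation counting, with a stated time of 20 min (on this read-out higher numbers stand for weaker inhibition and lower numbers for stronger inhibition), gives only a limit of the assay, > 10000 nM.
Compound 2, `Cc1ccc(N2CCN(CC(=O)Nc3nc4c(s3)CCCC4)CC2)cc1`, in this assay likewise gives only a limit, > 10000 nM.
Compound 3, `O=C(CN1CCN(c2ccccn2)CC1)Nc1nc2c(s1)CCCC2`, in this assay gives 4900 nM.

Going by the values given here, compound 3 thus holds the only actual number among the three; the other two values are limits, (the limit of > 10000 nM in this assay, at which 2 of the 3 values shown sit). The step of an at least 2.0-fold lower number from compound 1 to compound 3 (0.30 log units; that floor lies within the scatter) and the step of an at least 2.0-fold lower number from compound 2 to compound 3 (0.30 log units; that floor lies within the scatter) each reach only a floor that lies within the scatter, so they tell how far compound 3 stands from the limit but not how much further the true gap might be. Compound 4, `O=C(CN1CCN(c2nccs2)CC1)Nc1nc2c(s1)CCCC2`, differs from compound 3 in one place: 1,3-thiazol-2-yl in place of pyridin-2-yl on an amine nitrogen in a ring. Among the compounds with values here, no measured step covers this change; the two steps that do exist both run from a limit to the one number and cannot set a size for a new ring on the amine nitrogen. Within the data shown here, with nothing to lean on beyond the single number of compound 3, compound 4 is expected to show a step of a 1.1-fold higher number from compound 3 to compound 4 (0.05 log units; within the scatter), which stays within the scatter. Compound 4 is therefore estimated at 5500 nM in this assay, with a range from 2200 nM to 14000 nM.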

Compound 4, half-maximal inhibitory concentration: 7900 nM
Compound 4: middle estimate off by 1.4-fold (0.16 log units), on the low side, and the stated range covers the measured number.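

Going by these compounds alone, on the amine nitrogen in a ring, compound 4 gives the first step in this assay with a measured number at both ends (a 1.6-fold higher number from compound 3 to compound 4 (0.21 log units; within the scatter)). The five-membered 1,3-thiazol-2-yl ring, with its sulfur and its second ring hetero atom, can therefore stand in place of the six-membered pyridin-2-yl ring without a step beyond the scatter. Against the other two rings, only floors can be read (an at least 1.2-fold lower number from compound 2 to compound 4 (0.10 log units; that floor lies within the scatter) and an at least 1.2-fold lower number from compound 1 to compound 4 (0.10 log units; that floor lies within the scatter)), and both stay within the scatter because the values of compound 1 and compound 2 are limits, not numbers: (the limit of > 10000 nM in this assay, at which 2 of the 4 values shown sit).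

Still open, as far as these compounds go, is whether a pyrimidin-2-yl ring, a plain phenyl ring or an acetyl group on this same nitrogen would stay in the range of compound 3 and compound 4 or move clearly away from it. Also open, from the compounds shown here alone, is how a change elsewhere on the shared core, such as a methyl group on the amide nitrogen, would compare with these ring swaps.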